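The compounds below may be only part of what the source reports. "The series", "measured", "known", "first", "only" and "open" are said of these compounds alone.

Working notes on the series. In a functional assay (strain AB) with Danio rerio as the target, read by microscopy, with a stated time of 1 h (a lower number here means that less compound is needed, a higher number that more compound is needed for the effect), compound 3 (`CC[N+]1(CC2CC2)CCc2c(sc(NC(=O)Nc3ccc(Cl)cc3)c2C(N)=O)C1`) gives 100 nM, compound 1 (`C[N+]1(CC2CCCCC2)CCc2c(sc(NC(=O)Nc3ccc(Cl)cc3)c2C(N)=O)C1`) gives 100 nM and compound 2 (`CC(C)(C)OC(=O)CCCCC[N+]1(C)CCc2c(sc(NC(=O)Nc3ccc(Cl)cc3)c2C(N)=O)C1`) gives 110 nM. Compound 3 therefore shares the lowest number shown with compound 1, and all three values lie within the scatter of one another.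

The next compound is compound 4 (`CC[N+]1(C)CCc2c(sc(NC(=O)Nc3ccc(Cl)cc3)c2C(N)=O)C1`), with hydrogen in place of cyclopropyl on a saturated chain carbon bound to an amine nitrogen in a ring. The same difference reads as cyclopropylmethyl to methyl.

Among the compounds with values here, one measured step bears on this place. In a 1.1-fold higher number from compound 1 to compound 2 (0.04 log units; within the scatter), cyclohexyl gives way to 4-(tert-butoxycarbonyl)butyl, and the read-out in this assay stays within the scatter. That single step suggests that the number tolerates quite different groups here, though the evidence is thin. Within the data shown here, no measured step removes the group altogether, so a wide range is needed and only a slight lean towards a higher number is assumed.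

The expected change is a 1.3-fold higher number from compound 3 to compound 4 (0.11 log units; within the scatter), which means no step beyond the scatter is expected. For compound 4 the estimated value is 130 nM, with an expected range of 50 nM to 400 nM.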

Compound 4, half-maximal effective concentration: 1960 nM
For compound 4 the middle estimate is 15-fold (1.18 log units) below the measured one, and the stated range ends below it.
By their numbers in this assay, from the lowest: compounds 1, 3 and 2 (each within the scatter of the next); then compound 4.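

In this assay this position proves far from indifferent: cutting cyclopropylmethyl back to methyl gives a 20-fold higher number from compound 3 to compound 4 (1.29 log units; beyond the scatter) and the other two compounds show steps of like size, with an 18-fold higher number from compound 2 to compound 4 (1.25 log units; beyond the scatter) and with a 20-fold higher number from compound 1 to compound 4 (1.29 log units; beyond the scatter) as well. The earlier step between cyclohexyl and 4-(tert-butoxycarbonyl)butyl showed only that these two groups can replace each other within the scatter, whereas the new steps show that the tolerance ends once the chain carbon bound to the ring amine nitrogen carries hydrogen in place of such a group, and among the compounds shown none goes against this. Nothing at hand explains the size of these steps.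

The compounds shown leave open where between methyl and cyclopropylmethyl the number turns, which a plain longer chain such as propyl or butyl at this place would help to settle. They also leave open whether the chain needs its tert-butyl ester or whether a free carboxylic acid or an amine at its end would keep the number level with the other groups.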